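Phenyl for cyclohexyl on the ring nitrogen: compound 4

The source may hold more compounds than are shown below. What is called first, only, known or untested is meant among the compounds shown, and "the series" means these compounds.

Measured so far in a functional assay on PC-3 cells (Homo sapiens) for cytotoxicity, read by MTT assay, with a stated time of 48 h; on this read-out lower numbers stand for stronger inhibition and higher numbers for weaker inhibition:
compound 1, `[O-][n+]1nc(NCCO)[n+]([O-])c2ccccc21`: 22400 nM
compound 2, `COc1ccc(Nc2n[n+]([O-])c3ccccc3[n+]2[O-])cc1`: 12000 nM
compound 3, `[O-][n+]1nc(NC2CCCCC2)[n+]([O-])c2ccccc21`: 10500 nM

Compound 3 holds the lowest of the three numbers in this assay, but compound 2 cannot be separated from it, the gap being within the scatter. For the measured compounds named here, the only step beyond the scatter is a 2.1-fold lower number from compound 1 to compound 3 (0.33 log units; beyond the scatter). Compound 4, `[O-][n+]1nc(Nc2ccccc2)[n+]([O-])c2ccccc21`, differs from compound 3 by phenyl in place of cyclohexyl on a nitrogen on an aromatic ring. Going by the values given here, no step at this nitrogen from cyclohexyl to an aryl group has been measured; the value of compound 2, which carries an aryl group at the same nitrogen, sits close to that of compound 3, so no step beyond the scatter is expected. Compound 4 is therefore estimated at 11000 nM, between 5000 nM and 25000 nM. The expected step is a 1.0-fold higher number from compound 3 to compound 4 (0.02 log units; within the scatter).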

Compound 4, half-maximal inhibitory concentration: 17000 nM
For compound 4 the middle estimate is 1.5-fold (0.19 log units) below the measured one; measured number inside the range.
By their numbers in this assay, from the lowest: compounds 3, 2, 4 and 1 (each within the scatter of the next, the first and the last beyond it).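

In this assay phenyl in place of cyclohexyl on this nitrogen gives a 1.6-fold higher number from compound 3 to compound 4 (0.21 log units; within the scatter) and leaves the aromatic and non-aromatic six-membered rings unseparated. Phenyl in place of 2-hydroxyethyl gives a 1.3-fold lower number from compound 1 to compound 4 (0.12 log units; within the scatter), so phenyl, unlike cyclohexyl, is not separated from 2-hydroxyethyl, while hydrogen in place of methoxy on an aromatic carbon of the phenyl gives a 1.4-fold higher number from compound 2 to compound 4 (0.15 log units; within the scatter) and also separates nothing. No measurement bears on why these groups behave alike.

Open, from the compounds shown here alone, is whether a morpholine ring, a longer alkyl chain or a carboxylic acid on this nitrogen would give a step beyond the scatter from compound 3.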